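Series notes: from compound 2 to compound 4

The source may report more compounds than this note shows. Statements on the series, on what has been measured and on what is new or still open speak of the compounds shown alone.

The shared core carries an anilino-type nitrogen on one side and a styryl ketone on the other; compound 1 `COc1cccc(/C=C/C(=O)c2sc(Nc3cccc(C)c3)nc2C)c1`, compound 2 `Cc1nc(Nc2ccccc2)sc1C(=O)/C=C/c1ccc(Cl)cc1` and compound 3 `Cc1cccc(Nc2nc(C)c(C(=O)/C=C/c3ccccc3)s2)c1` have been measured in a functional assay on Bel-7402 cells (Homo sapiens) for cytotoxicity, read by MTT assay; on this read-out higher numbers stand for weaker inhibition and lower numbers for stronger inhibition. Compound 1 gives > 25000 nM, which is a limit of the assay and not a number. Compound 2 gives > 25000 nM, again a limit of the assay. Compound 3 gives > 25000 nM, also a limit. Going by the values given here, the one step between measured compounds, a step that the two limits leave unreadable from compound 1 to compound 3, is unreadable because of the limit of > 25000 nM in this assay, at which 3 of the 3 values shown sit. Compound 2 thus stands at the limit, with no number that would rank it against the other two.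

Compound 4 `Cc1nc(Nc2ccc(Cl)c(Cl)c2)sc1C(=O)/C=C/c1ccc(Cl)cc1` is not yet measured. It differs from compound 2 by 3,4-dichlorophenyl in place of phenyl on a nitrogen on an aromatic ring. Among the compounds with values here, no measured step touches the group on the ring nitrogen, and the only measured step, hydrogen in place of methoxy on an aromatic carbon, gave no readable size. For compound 4 the step that the limit leaves unreadable from compound 2 to compound 4 is therefore expected to be no more than a guess at parity. Compound 4 is estimated at 30000 nM, within 5000 nM to 120000 nM, most probably reported again as a limit.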

Compound 4, half-maximal inhibitory concentration: > 25000 nM
Compound 4 was reported as a limit; the forecaster's own chance of this, stated with the estimate: 75%; the middle value lies beyond the limit too.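

Compound 4 gives > 25000 nM as a limit of the assay, not a number. The step from compound 2 to compound 4 cannot be read, because both compounds stand at the limit: the limit of > 25000 nM in this assay, at which 4 of the 4 values shown sit.

The compounds shown leave open whether any change on the shared core brings a value inside the measurable range.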